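A few compounds are considered here, and "the series" means these few. Any claim that something is new, unique, unknown or untested is made for them only; others in the source may bear on it.

The three measured compounds are:

Compound 1, `COc1cc2c(Oc3ccc(NC(=O)c4nn(-c5ccccc5C)c(=O)cc4C)cc3F)ccnc2cc1OCCCN1CCC(C)CC1`, with 2240 nM in a functional assay on U-87MG ATCC cells (Homo sapiens) for inhibition, read by MTT assay, with a stated time of 72 h; a lower number here means a stronger inhibitor, a higher number a weaker inhibitor.
Compound 2, `COc1cc2c(Oc3ccc(NC(=O)c4nn(-c5ccccc5C)c(=O)cc4C)cc3F)ccnc2cc1OCCCN1CCN(C)CC1`, with 3720 nM in this assay.
Compound 3, `COc1cc2c(Oc3ccc(NC(=O)c4nn(-c5ccccc5C(F)(F)F)c(=O)cc4C)cc3F)ccnc2cc1OCCCN1CCC(C)CC1`, with 1120 nM in this assay.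

Compound 1 and compound 2 differ in one place: 4-methylpiperazin-1-yl in place of 4-methylpiperidin-1-yl on a saturated chain carbon, three bonds along the chain from an oxygen on an aromatic ring. That change gave a 1.7-fold higher number from compound 1 to compound 2 (0.22 log units; within the scatter). Compound 3 carries the core of compound 1 with one difference, (trifluoromethyl in place of methyl on an aromatic carbon), and this gave a 2.0-fold lower number from compound 1 to compound 3 (0.30 log units; within the scatter). Compound 2 shows a higher number than compound 3, and that gap lies beyond the scatter.

Compound 4, `COc1cc2c(Oc3ccc(NC(=O)c4nn(-c5ccccc5C(F)(F)F)c(=O)cc4C)cc3F)ccnc2cc1OCCCN1CCN(C)CC1`, has not yet been measured in this assay. It differs from compound 3 by 4-methylpiperazin-1-yl in place of 4-methylpiperidin-1-yl on a saturated chain carbon, three bonds along the chain from an oxygen on an aromatic ring, the same change that separates compound 1 from compound 2. Because that earlier change gave a 1.7-fold higher number from compound 1 to compound 2 (0.22 log units; within the scatter), a step of similar size is expected here, and compound 4 is estimated to come out at a 1.7-fold higher number from compound 3 to compound 4 (0.23 log units; within the scatter) from compound 3. The expectation rests on a single earlier example, so the range is kept wide. Compound 4 is expected to show about 1900 nM, between 900 nM and 4000 nM.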

Compound 4, half-maximal inhibitory concentration: 1170 nM
The estimate for compound 4 lay 1.6-fold (0.21 log units) above the measured number; measured number inside the range.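

In this assay, the swap to 4-methylpiperazin-1-yl on the trifluoromethyl core gave a 1.0-fold higher number from compound 3 to compound 4 (0.02 log units; within the scatter), and this step agrees with the same swap on the methyl core: the same change on two cores in this assay, a 1.7-fold higher number (0.22 log units; within the scatter) from compound 1 to compound 2 and a 1.0-fold higher number (0.02 log units; within the scatter) from compound 3 to compound 4, 1.6-fold (0.20 log units) apart, within the scatter of two such steps Trifluoromethyl in place of methyl, read on the 4-methylpiperazin-1-yl core, gave a 3.2-fold lower number from compound 2 to compound 4 (0.50 log units; beyond the scatter), and this step likewise agrees with its earlier counterpart: the same change on two cores in this assay, a 2.0-fold lower number (0.30 log units; within the scatter) from compound 1 to compound 3 and a 3.2-fold lower number (0.50 log units; beyond the scatter) from compound 2 to compound 4, 1.6-fold (0.20 log units) apart, within the scatter of two such steps Within these four compounds, each change therefore carries from one core to the other without a difference that can be told from the scatter, but this rests on a single pair of steps per change and does not show that either change would carry over to any other core in the series.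

The compounds shown leave open whether the same agreement would hold with a morpholine or a dimethylamine at the end of the chain, or with a shorter chain than the propyl linker. They also leave open how a chlorine or a methoxy group would compare with trifluoromethyl on that aromatic carbon.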